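This account rests on a few compounds, and the source may have more. Where it says the series, first, only, none or still open, it means among the compounds named here.

Measured in a functional assay on MCF7 cells (Homo sapiens) for antiproliferative activity, read by cell counting, with a stated time of 4 days; a lower number here means a stronger inhibitor, a higher number a weaker inhibitor:

- Compound 1 `CCOC(=O)CN(Cc1cc(F)cc(F)c1)c1ccc2c(c1)N(C)CC(C)(COc1ccc(C#N)cc1)O2`: > 100000 nM (a limit)
- Compound 2 `CCOC(=O)CN(Cc1cccc(F)c1)c1ccc2c(c1)N(C)CC(C)(COc1ccc(C(=N)N)cc1)O2`: 4200 nM

Among the measured compounds shown here, only one real number is available so far: in this assay, compound 2 gives 4200 nM. Compound 1 gives > 100000 nM, which is a limit of the assay and not a number.

The next compound to be tested is compound 3 `CCOC(=O)CN(Cc1cccc(F)c1)c1ccc2c(c1)N(C)CC(C)(COc1ccc(C#N)cc1)O2`. It differs from compound 2 at a single place, on an aromatic carbon of a six-membered aromatic ring of carbon only, para to a large group: a group of 2 heavy atoms (1 carbon, 1 nitrogen; no ring) in place of a group of 3 heavy atoms (1 carbon, 2 nitrogen; no ring), on an aromatic carbon. The group that enters is cyano.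

For the measured compounds named here, no measured pair shows this exchange on its own, so the forecast rests on thin evidence. A large step towards weaker inhibition is expected, because compound 1 also carries cyano and reads > 100000 nM. The expected change is a 9.5-fold higher number from compound 2 to compound 3 (0.98 log units; beyond the scatter). For compound 3 the estimate is 40000 nM, with an expected range of 8000 nM to 100000 nM. A result reported only as a limit in this assay would also be no surprise.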

Compound 3, half-maximal inhibitory concentration: > 100000 nM
Compound 3 gave a limit, no number; the forecaster's own chance of this, stated with the estimate: 55%; at least 2.5-fold (0.39 log units) between middle value and limit.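

Among the compounds shown here, this is the first pair to isolate the change at this position: in this assay, cyano in place of the group of 3 heavy atoms (1 carbon, 2 nitrogen), on the aromatic carbon para to a large group, gives an at least 23-fold higher number from compound 2 to compound 3 (1.37 log units; beyond the scatter). Earlier, compound 1 carried cyano but also differed from compound 2 in its fluoro pattern, so this single exchange could not be separated from that difference. Compound 3 reads as a limit and not a number, so the printed step is only a lower bound on the true change: the limit of > 100000 nM in this assay, at which 2 of the 3 values shown sit.

As far as these compounds go, the step between compound 1 and compound 3, hydrogen in place of fluoro, cannot be read, as both compounds stand at a limit, so the role of the second fluoro remains unknown while cyano is present. The compounds shown also leave open whether a primary amine, a carboxylic acid or a primary amide at this ring position would give a measurable number, and whether a second fluoro would alter the value of compound 2.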